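Tert-butyl for chloro on the thiophene of compound 2

The source may hold more compounds than are shown below. What is called first, only, known or untested is meant among the compounds shown, and "the series" means these compounds.

Working notes on an aminothiophene series on a shared bicyclic core. In an ADME assay on MDCK cells (Canis lupus familiaris) for cytotoxicity, read by microscopy, with a stated time of 48 h (on this read-out lower numbers stand for higher toxicity in this test and higher numbers for lower toxicity in this test), compound 1 `CCc1ccc(CN[C@@H]2C[C@H]3C[C@@H]([C@H]2C)C3(C)C)s1` gives 1560 nM. Compound 2 `C[C@H]1[C@H](NCc2ccc(Cl)s2)C[C@H]2C[C@@H]1C2(C)C` gives 25000 nM, the highest of the two plain numbers in this assay; its nearest neighbour is compound 1, a step of a 16-fold higher number from compound 1 to compound 2 (1.20 log units; beyond the scatter). Compound 3 `C[C@H]1[C@H](NCc2nccs2)C[C@H]2C[C@@H]1C2(C)C` is reported only as a limit in this assay, > 100000 nM, as noted in the limit of > 100000 nM in this assay, at which 1 of the 3 values shown sits.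

The step now considered leads from compound 2 to compound 4 `C[C@H]1[C@H](NCc2ccc(C(C)(C)C)s2)C[C@H]2C[C@@H]1C2(C)C`: tert-butyl in place of chloro on an aromatic carbon. Within the data shown here, of the measured steps, the one from compound 1 to compound 2 bears most on it, since it also exchanges an alkyl group and a chloro at the same aromatic carbon, and it was large, a 16-fold higher number from compound 1 to compound 2 (1.20 log units; beyond the scatter); the step from compound 2 to compound 3, an at least 4.0-fold higher number from compound 2 to compound 3 (0.60 log units; beyond the scatter), exchanges the whole ring and is less informative here. Running the alkyl-for-chloro exchange in the opposite sense, a step downward in this assay of roughly similar size is expected, a 17-fold lower number from compound 2 to compound 4 (1.22 log units; beyond the scatter). Compound 4 is therefore estimated at 1500 nM, with a range from 300 nM to 7000 nM.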

Compound 4, minimum cytotoxic concentration: 780 nM
Estimate against measurement, compound 4: 1.9-fold (0.28 log units) above; the range from low to high includes it.
By their numbers in this assay, from the lowest: compounds 4 and 1 (each within the scatter of the next); then compound 2. At a limit, above all of these: compound 3.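

In this assay the exchange at this aromatic carbon next to the ring sulfur is now read in both directions on the same thiophene: tert-butyl in place of chloro gives a 32-fold lower number from compound 2 to compound 4 (1.51 log units; beyond the scatter). This confirms that the large gap between compound 1 and compound 2 is not tied to ethyl alone. Tert-butyl in place of ethyl gives a 2.0-fold lower number from compound 1 to compound 4 (0.30 log units; within the scatter) and compound 1 and compound 4 therefore cannot be told apart on this read-out, so for these two alkyl groups the change from ethyl to tert-butyl has no readable effect. Among the thiophenes shown, compound 2 with its chloro is the one that stands apart from the two alkyl compounds, and that holds for these three compounds only.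

Going by these compounds, whether that higher number belongs to chloro in particular or extends to other groups at this place, such as a methoxy, a nitrile, an amine or a carboxylic acid, stays open. Nothing shown gives a measured property that would account for the gap between chloro and the two alkyl groups.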